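Arylsulfonyl variation in a quinoline series at the glutamate receptor

A few compounds are considered here, and "the series" means these few. Any claim that something is new, unique, unknown or untested is made for them only; others in the source may bear on it.

Measured compounds:
- compound 1 `CC1CCN(c2c(S(=O)(=O)c3cc(F)cc(F)c3)cnc3cc(F)ccc23)CC1`: 77%
- compound 2 `Cc1ccc2ncc(S(=O)(=O)c3ccc(F)cc3)c(N3CCC(C)CC3)c2c1`: 90%
- compound 3 `CC1CCN(c2c(S(=O)(=O)c3ccc(F)cc3)cnc3cc(Cl)ccc23)CC1`: 91%

Of the compounds shown here, three have been measured in an assay on isolated protein for displacement of a labelled ligand from metabotropic glutamate receptor 5 (Homo sapiens), with a stated time of 60 min, tested at 1 uM; on this read-out higher numbers stand for more inhibition at the one concentration tested (going by the name of the read-out) and lower numbers for less inhibition. Compound 2 gives 90%, which is the second highest of the three numbers. Its nearest neighbour is compound 3, whose value in this assay is 91%, a number within the scatter of that of compound 2. Compound 1 stands furthest away, giving 77% in this assay, a gap from compound 2 beyond the scatter. Within the data shown here, no pair among the measured compounds differs in a single place, so no measured step can be drawn on.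

Compound 4 `Cc1ccc2ncc(S(=O)(=O)c3ccc(C)c(Cl)c3)c(N3CCC(C)CC3)c2c1` has not yet been measured. It differs from compound 2 in this way: 3-chloro-4-methylphenyl in place of 4-fluorophenyl on a sulfonyl sulfur. Compounds 1, 2 and 3 all carry fluorine-bearing rings on that sulfonyl sulfur, so the data give no direct guide to a chlorine and methyl pattern there. The step of a number 8 percentage points lower from compound 2 to compound 4 (within the scatter) is expected to be small, toward a slightly lower number or none beyond the scatter. Compound 4 is estimated to give 82% in this assay, between 55% and 97%.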

Compound 4, a percentage reported as inhibition, at one concentration (the size of the read-out at that concentration, not a potency): 91%
Estimate against measurement, compound 4: 9 percentage points below, and the stated range covers the measured number.
By their numbers in this assay, from the lowest: compound 1; then compounds 2, 3 and 4 (each within the scatter of the next).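

In this assay, among these compounds, 3-chloro-4-methylphenyl in place of 4-fluorophenyl on a sulfonyl sulfur gives a number 1 percentage points higher from compound 2 to compound 4 (within the scatter), the first step that can be read at this position. It shows that, with the rest of compound 2 held fixed, the ring on the sulfonyl sulfur need not carry fluorine: a ring bearing chlorine and methyl reads within the scatter of the fluorinated one. Nothing at hand accounts for this result.

From the compounds shown here alone, both numbers come from one tested concentration, so whether the potencies of compound 2 and compound 4 differ remains open. Also open, going by these compounds, is how this position would respond to a ring carrying an amine or a carboxylic acid, or to a longer chain on the sulfonyl sulfur.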